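A few compounds are considered here, and "the series" means these few. Any claim that something is new, unique, unknown or untested is made for them only; others in the source may bear on it.

Among the measured compounds shown here, compound 2, `O=C(Nc1nc(-c2cccc(F)c2)cs1)c1ccc([N+](=O)[O-])o1`, is one of two compounds measured in an ADME assay on Vero cells (Chlorocebus sabaeus) for cytotoxicity, read by MTT assay, with a stated time of 72 h; a lower number here means a stronger inhibitor, a higher number a weaker inhibitor. In this assay compound 2 gives 51600 nM, the higher of the two numbers, though its nearest neighbour, compound 1, `COc1ccccc1-c1csc(NC(=O)c2ccc([N+](=O)[O-])o2)n1`, gives 42000 nM, and the step of a 1.2-fold higher number from compound 1 to compound 2 (0.09 log units; within the scatter) lies within the scatter, so the two cannot be told apart.

Compound 3, `CCOc1cccc(-c2csc(NC(=O)c3ccc([N+](=O)[O-])o3)n2)c1`, differs from compound 2 in one place: ethoxy in place of fluoro on an aromatic carbon. For the measured compounds named here, the only measured step that bears on this change is the one from compound 1 to compound 2, where a substituent on the same carbon-only ring was exchanged, and that step, a 1.2-fold higher number from compound 1 to compound 2 (0.09 log units; within the scatter), stayed within the scatter. Going by the values given here, nothing measured so far shows a change on that ring moving the number in this assay beyond its ordinary spread, and no step with an ethoxy group has been measured at all.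

On that basis, compound 3 is expected to give about 48000 nM in this assay, with a range from 22000 nM to 105000 nM. The step from compound 2 that this estimate implies, a 1.1-fold lower number from compound 2 to compound 3 (0.03 log units; within the scatter), is expected to fall within the scatter.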

Compound 3, half-maximal inhibitory concentration: > 90000 nM
Compound 3: no number, only a limit; the forecaster's own chance of this, stated with the estimate: 10%; at least 1.8-fold (0.27 log units) between middle value and limit.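

Among the compounds shown here, compound 3 is the only one of the three compounds that gives a limit of the assay rather than a number in this assay: the limit of > 90000 nM in this assay, at which 1 of the 3 values shown sits. Ethoxy in place of fluoro, on an aromatic carbon of the six-membered aromatic ring of carbon only and meta to a large group, gives an at least 1.7-fold higher number from compound 2 to compound 3 (0.24 log units; that floor lies within the scatter), which shows what the earlier pair could not: this place accepts a group of three heavy atoms with one hydrogen-bond acceptor without the number in this assay falling below that of compound 2. The step is one-sided, however, and its floor does not settle whether the true difference lies beyond the ordinary spread, so it shows a direction that is possible rather than a size.

Going by these compounds, whether an amine, a carboxylic acid or a chain longer than ethoxy at this same place would leave the number in this assay as high, or bring it down to a measurable value, remains open. Also open, on these data alone, is whether the fluoro and ethoxy compounds truly differ, as only a number for compound 3 in place of its limit could decide that.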